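The source may hold more compounds than are shown below. What is called first, only, known or untested is meant among the compounds shown, and "the series" means these compounds.

Working notes on the series, with all numbers taken from a functional assay on ACHN cells (Homo sapiens) for inhibition (on this read-out lower numbers stand for stronger inhibition of growth and higher numbers for weaker inhibition of growth), as the only read-out. Compound 1 (`COc1cc(/C=C/c2ccc(S(N)(=O)=O)cc2)cc(OC)c1`) gives 23500 nM as its value and compound 2 (`NS(=O)(=O)c1ccc(/C=C/c2ccc(O)c(O)c2)cc1`) gives 20400 nM as its value, and these two lie within the usual scatter of each other. Compound 3 (`NS(=O)(=O)c1ccc(/C=C/c2ccc(F)cc2)cc1`) has the lowest number of the three, with 2970 nM as its value, and its distance to each of the other two lies beyond the scatter.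

The next compound is compound 4 (`NS(=O)(=O)c1ccc(/C=C/c2ccc(O)cc2)cc1`), which has not yet been measured. Its change from compound 3 is hydroxy in place of fluoro on an aromatic carbon, para to a large group (hydroxy in place of fluoro on an aromatic carbon). Going by the values given here, no two measured compounds differ in one place only, so no direct step is available as a guide. The nearest evidence is compound 2 (20400 nM), which also bears hydroxy, although compound 1 (23500 nM) has no hydroxy and shows a similar number.

A move towards weaker inhibition of growth is expected, probably beyond the scatter but short of the full gap to compound 2. The expected size is a 2.7-fold higher number from compound 3 to compound 4 (0.43 log units; beyond the scatter) on this estimate. For compound 4 the estimated value is 8000 nM within an expected range of 2800 nM to 22000 nM overall.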

Compound 4, concentration for 50% growth inhibition: 2280 nM
Estimate against measurement, compound 4: 3.5-fold (0.55 log units) above, outside the stated range (below it).
By their numbers in this assay, from the lowest: compounds 4 and 3 (each within the scatter of the next); then compounds 2 and 1 (each within the scatter of the next).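

In this assay, swapping fluoro for hydroxy on an aromatic carbon, para to a large group, gives a 1.3-fold lower number from compound 3 to compound 4 (0.11 log units; within the scatter), so this read-out does not separate the two groups at this place. Hydroxy at this place therefore does not by itself go with a high number, which the earlier compounds could not show, as compound 2 was the only hydroxy-bearing compound among them and carried a further hydroxy. Going by these compounds alone, the first one-place step on that compound gives an 8.9-fold lower number from compound 2 to compound 4 (0.95 log units; beyond the scatter) with hydrogen in place of hydroxy on an aromatic carbon, so the large change in this pair lies with the extra hydroxy of compound 2 and not with the hydroxy that compound 4 shares with it.

No supporting data are at hand to explain why one hydroxy exchange changes the number so little and the other so much. On these data alone, whether an amine, a carboxylic acid or a longer chain such as propoxy at the place para to the large group would also stay within the scatter of compound 3 and compound 4 remains open, and with only these two groups at this place no trend across substituents can be drawn.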